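The compounds below may be only part of what the source reports. "The series", "measured", "known", "first", "only" and "open" are said of these compounds alone.

Compound 2, `C=Cc1ccsc1CN[C@@H]1C[C@H]2C[C@@H]([C@H]1C)C2(C)C`, and compound 1, `CCCCc1csc(CN[C@@H]2C[C@H]3C[C@@H]([C@H]2C)C3(C)C)c1`, share one core and differ only in the group on the thiophene carbon. In an ADME assay on MDCK cells (Canis lupus familiaris) for cytotoxicity, read by microscopy, with a stated time of 48 h (on this read-out higher numbers stand for lower toxicity in this test and lower numbers for higher toxicity in this test), compound 2 gives 50000 nM, the highest of the two numbers measured; compound 1 gives 12500 nM in this assay, a step that lies beyond the usual scatter. Compound 3, `C[C@H]1[C@H](NCc2sccc2-c2ccccc2)C[C@H]2C[C@@H]1C2(C)C`, has not yet been measured. It differs from compound 2 in one place: phenyl in place of vinyl on an aromatic carbon. Among the compounds with values here, no step between measured compounds isolates this kind of change, so the expectation rests only on the two values shown, where compound 1 with its butyl group reads lower than compound 2 with its vinyl group. Compound 3 is expected to move in the same direction, by a 2.0-fold lower number from compound 2 to compound 3 (0.30 log units; within the scatter) in this assay. The estimate for compound 3 in this assay is 25000 nM, within a range from 6000 nM to 100000 nM.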

Compound 3, minimum cytotoxic concentration: 12500 nM
Compound 3: middle estimate off by 2.0-fold (0.30 log units), on the high side; measured number inside the range.
By their numbers in this assay, from the lowest: compounds 1 and 3 (each within the scatter of the next); then compound 2.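

In this assay, within the data shown here, the change from vinyl to phenyl on this aromatic carbon, two ring bonds from the ring sulfur, gives a 4.0-fold lower number from compound 2 to compound 3 (0.60 log units; beyond the scatter) and is the first step that isolates a single change at this position. The step lies beyond the scatter, so this place on the ring does respond to the group it carries in this test. Phenyl brings a six-membered aromatic ring of carbon only where vinyl had no ring, while the counts of hydrogen-bond donors and acceptors and the net charge stay the same, and nothing at hand gives a measured reason for the lower number.

The compounds shown leave open how a saturated ring such as cyclohexyl or a pyridine ring would read at this carbon. They also leave open what a carboxylic acid or an amine on the phenyl would do to the number.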